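Oxygen substituents on the shared core: compound 3 to compound 4

This account rests on a few compounds, and the source may have more. Where it says the series, first, only, none or still open, it means among the compounds named here.

In a functional assay on HepG2 cells (Homo sapiens) for cytotoxicity, read by MTT assay (on this read-out lower numbers stand for stronger inhibition and higher numbers for weaker inhibition), compound 1 `COc1ccc(/C=C/C(=O)c2ccc(OC)c3c2OC(C)(C)C=C3)cc1O` gives 450 nM and compound 3 `COc1ccc(/C=C/C(=O)c2ccc(OC)c3c2OC(C)(C)C=C3)cc1OC(=O)c1ccc(Br)cc1` gives 680 nM, two values within the scatter of each other. Compound 2 `C=CCOc1cc(/C=C/C(=O)c2ccc(OC)c3c2OC(C)(C)C=C3)ccc1OC` reads > 10000 nM, which is a limit of this assay and not a number. Compound 4 `COc1ccc(/C=C/C(=O)c2ccc(OC)c3c2OC(C)(C)C=C3)cc1OS(=O)(=O)Cc1ccccc1` carries benzylsulfonyl in place of (4-bromophenyl)carbonyl on an oxygen on an aromatic ring. Two measured steps on this oxygen bear on it and disagree: a 1.5-fold higher number from compound 1 to compound 3 (0.18 log units; within the scatter) stays within the scatter, whereas an at least 22-fold higher number from compound 1 to compound 2 (1.34 log units; beyond the scatter) is large. The first is taken as the nearer guide, with the second widening the range upward. The expected step is a 1.8-fold higher number from compound 3 to compound 4 (0.25 log units; within the scatter). For compound 4 the estimated value is 1200 nM, with an expected range of 250 nM to 7000 nM.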

Compound 4, half-maximal inhibitory concentration: > 10000 nM
Compound 4: a limit, no number; the forecaster's own chance of this, stated with the estimate: 15%; middle value at least 8.3-fold (0.92 log units) away from the limit.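

In this assay benzylsulfonyl in place of (4-bromophenyl)carbonyl on this oxygen gives an at least 14-fold higher number from compound 3 to compound 4 (1.16 log units; beyond the scatter) and shows that the tolerance seen with compound 3 does not carry over to every group with one six-membered aromatic ring. Benzylsulfonyl in place of hydrogen gives an at least 22-fold higher number from compound 1 to compound 4 (1.34 log units; beyond the scatter) as well, which leaves (4-bromophenyl)carbonyl as the only one of the three groups shown on this oxygen that stays within the scatter of compound 1.

As far as these compounds go, whether acetyl, benzoyl or methanesulfonyl on this oxygen would keep the level of compound 3 stays open. Allyl and benzylsulfonyl cannot be ranked, and the step from compound 2 to compound 4 cannot be read, as both compounds stand at one limit and not at a number: the limit of > 10000 nM in this assay, at which 2 of the 4 values shown sit.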